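The source may hold more compounds than are shown below. What is called first, only, known or untested is meant among the compounds shown, and "the series" means these compounds.

Measured compounds in a functional assay on HeLa cells (Homo sapiens) for antiproliferative activity, read by MTT assay, with a stated time of 48 h, in the presence of a further agent that is not named here; on this read-out higher numbers stand for weaker inhibition of growth and lower numbers for stronger inhibition of growth:
- compound 1 `COc1ccc(-c2nn(-c3ccccc3)cc2C(=O)NOCc2ccccc2)cc1` gives 2640 nM
- compound 2 `COc1ccc(-c2nn(-c3ccccc3)cc2C(=O)NOCc2ccccc2F)cc1` gives 2900 nM
- compound 3 `COc1ccc(-c2nn(-c3ccccc3)cc2C(=O)NOCc2ccccc2Cl)cc1` gives 3480 nM

Compound 3 holds the highest of the three numbers in this assay, but the gaps are small: a 1.3-fold higher number from compound 1 to compound 3 (0.12 log units; within the scatter) and a 1.2-fold higher number from compound 2 to compound 3 (0.08 log units; within the scatter), both within the scatter, as is a 1.1-fold higher number from compound 1 to compound 2 (0.04 log units; within the scatter). On this read-out the three compounds cannot be told apart, and no ordering among them is claimed.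

Compound 4 `O=C(NOCc1ccccc1Cl)c1cn(-c2ccccc2)nc1-c1ccc(Cl)cc1` differs from compound 3 on the ring at the far side of the shared core: chloro in place of methoxy on an aromatic carbon, at an aromatic carbon para to a large group. Among the compounds with values here, none of the measured steps touches this ring. All three concern the ring where fluoro and chloro replaced hydrogen, and each left the number unchanged within the scatter. Within the data shown here, there is therefore no direct precedent for exchanging methoxy for chloro here, only the general observation that substituent changes have so far moved the number little.

The expected step is a 1.0-fold higher number from compound 3 to compound 4 (0.00 log units; within the scatter), none beyond the scatter. Compound 4 is estimated at 3500 nM, with a range from 1500 nM to 8000 nM.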

Compound 4, concentration for 50% growth inhibition: 8850 nM
Compound 4: middle estimate off by 2.5-fold (0.40 log units), on the low side; measured number outside the range, above it.
By their numbers in this assay, from the lowest: compounds 1, 2 and 3 (each within the scatter of the next); then compound 4.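

In this assay, within the data shown here, the exchange of 4-methoxyphenyl for 4-chlorophenyl gives a 2.5-fold higher number from compound 3 to compound 4 (0.41 log units; beyond the scatter) and is the first step to lie beyond the scatter, though it is modest and points towards weaker inhibition of growth. Substitution on an aromatic carbon para to a large group can therefore move the number, whereas the fluoro and chloro changes on the other ring left it within the scatter; this rests on a single pair, compound 3 and compound 4, and is no general rule for the position. Nothing available bears on why the number moves with this exchange.

The compounds shown leave open whether the same exchange has a similar effect when the other ring carries hydrogen or fluoro instead of chloro, as the change is seen here only with chloro on that ring. They also leave open how this position responds to other groups, such as an amine, a hydroxy group or a carboxylic acid, and hence whether methoxy is favoured or chloro is specifically disfavoured.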